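Tolerability notes on the shared-core amides

This account rests on a few compounds, and the source may have more. Where it says the series, first, only, none or still open, it means among the compounds named here.

Measured compounds in an ADME assay on Vero cells (Chlorocebus sabaeus) for cytotoxicity, read by XTT assay, with a stated time of 72 h; a higher number here means that more compound is tolerated, a lower number that less compound is tolerated:
- compound 1, `CC1=C(C(=O)Nc2ccc(Br)cc2)C(c2ccccc2)NC(=O)N1`, gives > 100000 nM, which is a limit.
- compound 2, `CC1=C(C(=O)NC2CCCCC2)C(c2ccccc2)NC(=O)N1`, gives > 100000 nM, which is a limit.
- compound 3, `CC1=C(C(=O)Nc2ccccc2Cl)C(c2ccccc2Br)NC(=O)N1`, gives > 100000 nM, which is a limit.

Compound 3 therefore stands only at a limit in this assay, and the two other values shown are limits as well; all three sit at the limit of > 100000 nM in this assay, at which 3 of the 3 values shown sit. Within the data shown here, the one step among measured compounds, a step that the two limits leave unreadable from compound 1 to compound 2, cannot be read because both ends are limits.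

Compound 4, `CC1=C(C(=O)Nc2ccccc2Cl)C(c2ccc(C)cc2)NC(=O)N1`, differs from compound 3 by 4-methylphenyl in place of 2-bromophenyl on a saturated ring carbon. Among the measured compounds shown here, no measured step touches this position, and the only step available is unreadable, so no size can be drawn from it. With every value shown sitting at the limit of > 100000 nM in this assay, at which 3 of the 3 values shown sit, the expectation is that compound 4 behaves no differently beyond the scatter in this assay, the change expected as a step that the limit leaves unreadable from compound 3 to compound 4. Compound 4 is thus estimated at 150000 nM, within 70000 nM to 400000 nM, most likely reported again as a limit.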

Compound 4, half-maximal cytotoxic concentration: > 100000 nM
Compound 4 ended at the assay's limit; the forecaster's own chance of this, stated with the estimate: 85%; the middle value is on the limit's open side.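

No step can be read between compound 3 and compound 4 in this assay, because both values are limits, and the series stays at a single limit: the limit of > 100000 nM in this assay, at which 4 of the 4 values shown sit.

The compounds shown leave open at what concentration any of them becomes cytotoxic, and whether 4-methylphenyl in place of 2-bromophenyl changes tolerance at all.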